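The source may report more compounds than this note shows. Statements on the series, on what has been measured and on what is new or still open speak of the compounds shown alone.

Working notes on the series. Compound 1 `CCN(Cc1ccoc1)C(=O)COc1ccc(C)cc1` and compound 2 `Cc1ccc(OCC(=O)N(Cc2cccs2)c2ccccn2)cc1` share one core and differ in the group carried on a saturated chain carbon bound to an amide-type nitrogen. In an assay on HEK293 cells for agonist activity at transient receptor potential cation channel subfamily M member 8 (Homo sapiens), read by fluorescence and calcium flux, with a stated time of 15 min (a lower number here means that less compound is needed, a higher number that more compound is needed for the effect), compound 1 gives 136 nM. In this assay compound 2 gives 200 nM. Compound 1 has the lowest of the two numbers, though the distance to compound 2 falls within the scatter and does not rank the pair.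

Compound 3 `CCN(Cc1ccncc1)C(=O)COc1ccc(C)cc1` is the next member and has not yet been measured. Its difference from compound 1 is pyridin-4-yl in place of furan-3-yl on a saturated chain carbon bound to an amide-type nitrogen. For the measured compounds named here, no step between measured compounds covers this change, so the expectation rests only on the two values in hand, which show a narrow spread across two different groups at this place. A step of modest size is expected, toward a higher number or none beyond the scatter, and the estimate means a step of a 1.5-fold higher number from compound 1 to compound 3 (0.19 log units; within the scatter). Compound 3 is expected to give 210 nM in this assay, with a range from 70 nM to 650 nM.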

Compound 3, half-maximal effective concentration: "not active" (no number reported)
For compound 3 the study gives words and no number; the estimate stays without a comparison.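

For the compounds shown here, compound 3 has words and no number in this assay, so no step from compound 1 can be read. The compounds shown leave open how far a (pyridin-4-yl)methyl group in place of (furan-3-yl)methyl shifts the number, and whether compound 3 would give any number at all. Nothing measured bears on this result.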